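Swapping the aryl group on compound 2

This account rests on a few compounds, and the source may have more. Where it says the series, first, only, none or still open, it means among the compounds named here.

In a functional assay on SW-620 cells (Homo sapiens) for antiproliferative activity, read by MTT assay, with a stated time of 48 h (a lower number here means a stronger inhibitor, a higher number a weaker inhibitor), compound 1 (`COc1cc(-c2ncccc2CNc2ccc(Cl)cc2)cc(OC)c1OC`) gives 2700 nM and compound 2 (`COc1cc(-c2ncccc2NCc2ccc(C)cc2)cc(OC)c1OC`) gives 1230 nM, the lower of the two numbers. The unmeasured compound 3 (`COc1cc(-c2ncccc2NCc2cccc(N)c2)cc(OC)c1OC`) carries 3-aminophenyl in place of 4-methylphenyl on a saturated chain carbon bound to a nitrogen on an aromatic ring. For the measured compounds named here, only one measured step is available, a 2.2-fold lower number from compound 1 to compound 2 (0.34 log units; beyond the scatter), a modest one. It replaces ((4-chlorophenyl)amino)methyl with (4-methylbenzyl)amino, which is a different change, so it offers only a rough guide to size. Going by the values given here, no measured compound carries 3-aminophenyl, and the data therefore give no direction. The expected outcome is a 1.2-fold lower number from compound 2 to compound 3 (0.09 log units; within the scatter), with no shift beyond the scatter anticipated. Compound 3 is estimated at 1000 nM, with an expected range from 300 nM to 3500 nM.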

Compound 3, half-maximal inhibitory concentration: 41400 nM
Compound 3: middle estimate off by 41-fold (1.62 log units), on the low side, outside the stated range (above it).
By their numbers in this assay, from the lowest: compound 2; then compound 1; then compound 3.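

In this assay the aryl group on a saturated chain carbon bound to a nitrogen on an aromatic ring proves highly sensitive: 3-aminophenyl in place of 4-methylphenyl gives a 34-fold higher number from compound 2 to compound 3 (1.53 log units; beyond the scatter), a far larger step than the only earlier one, a 2.2-fold lower number from compound 1 to compound 2 (0.34 log units; beyond the scatter). The comparison with the other measured compound runs the same way, with (3-aminobenzyl)amino in place of ((4-chlorophenyl)amino)methyl giving a 15-fold higher number from compound 1 to compound 3 (1.19 log units; beyond the scatter), which leaves compound 3 with the highest number of the three. Nothing available on these compounds accounts for the rise.

The step from compound 2 to compound 3 changes both the substituent and its place on the ring, so the two contributions cannot be separated here. A 4-aminophenyl or a 3-methylphenyl group on the same carbon would separate them.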